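The compounds below may be only part of what the source reports. "The series", "measured", "known", "first", "only" and "open" are said of these compounds alone.

Series notes. Compound 2 `CCc1cc(C(C)=O)c(O)cc1OCCCCCCC(C)(C)c1nnn[nH]1` stands at 13% in an assay on isolated protein for binding affinity to leukotriene B4 receptor (Homo sapiens), tested at 0.1 uM (a higher number here means more inhibition at the concentration tested (going by the name of the read-out), a lower number less inhibition), with compound 1 `CCc1cc(C(C)=O)c(O)cc1OCCCCCCCC(C)(C)C#N` alongside at 6%; the step of a number 7 percentage points higher from compound 1 to compound 2 (within the scatter) is within the scatter, so the two are not separable on these numbers. Compound 3 `CCc1cc(C(C)=O)c(O)cc1OCCCCCC(C)(C)c1nnnn1C` differs from compound 2 by 1-methyl-1-(1-methyl-1H-tetrazol-5-yl)ethyl in place of 2-(1H-tetrazol-5-yl)-2-methylpropyl on a saturated chain carbon, five bonds along the chain from an oxygen on an aromatic ring. For the measured compounds named here, no measured step bears directly on this change; the only step available, from compound 1 to compound 2, was within the scatter. With nothing pointing either way, no step beyond the scatter in this assay is expected for compound 3, so the estimate is 12%, with a range from 2% to 26%; the expected step is a number 1 percentage points lower from compound 2 to compound 3 (within the scatter).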

Compound 3, a percentage reported as inhibition, at one concentration (the size of the read-out at that concentration, not a potency): 14%
Compound 3: the middle estimate sits 2 percentage points below what was measured, within the range that was stated.
By their numbers in this assay, from the lowest: compounds 1, 2 and 3 (each within the scatter of the next).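

At the saturated chain carbon five bonds along the chain from an oxygen on an aromatic ring, 1-methyl-1-(1-methyl-1H-tetrazol-5-yl)ethyl gives a number 1 percentage points higher from compound 2 to compound 3 (within the scatter) in this assay, so exchanging a group with 1 hydrogen-bond donor for one with 0 hydrogen-bond donors does not separate the pair. Against the nitrile, the same group gives a number 8 percentage points higher from compound 1 to compound 3 (within the scatter), leaving all three compounds unresolved. No supporting measurement bears on these readings. As far as these compounds go, whether a carboxylic acid in place of the tetrazole would give a step beyond the scatter remains open.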